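Aryl variation on the hydrazone of a quinoline ether series

A few compounds are considered here, and "the series" means these few. Any claim that something is new, unique, unknown or untested is made for them only; others in the source may bear on it.

Measured compounds:
- compound 1 `COc1ccc(/C=N/NC(=O)Nc2ccc(Oc3ccnc4cc(OCCCN5CCCCC5)c(OC)cc34)c(F)c2)cc1`: 540 nM
- compound 2 `COc1cc2c(Oc3ccc(NC(=O)N/N=C/c4ccc(C(F)(F)F)cc4)cc3F)ccnc2cc1OCCCN1CCCCC1`: 660 nM
- compound 3 `COc1cc2c(Oc3ccc(NC(=O)N/N=C/c4ccc(F)cc4Cl)cc3F)ccnc2cc1OCCCN1CCCCC1`: 130 nM

All values are from a functional assay on A549 cells (Homo sapiens) for cytotoxicity, read by MTT assay, with a stated time of 72 h; on this read-out higher numbers stand for weaker inhibition and lower numbers for stronger inhibition. Compound 3 gives the lowest number of the three; its nearest neighbour is compound 1 and the step of a 4.2-fold lower number from compound 1 to compound 3 (0.62 log units; beyond the scatter), while the step of a 5.1-fold lower number from compound 2 to compound 3 (0.71 log units; beyond the scatter) is somewhat larger. Between compounds 1 and 2 the step of a 1.2-fold higher number from compound 1 to compound 2 (0.09 log units; within the scatter), so methoxy and trifluoromethyl on the aryl ring of the hydrazone behave alike.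

Compound 4 `COc1cc2c(Oc3ccc(NC(=O)N/N=C/c4ccc(OC(F)(F)F)cc4)cc3F)ccnc2cc1OCCCN1CCCCC1` is not yet measured in this assay. It differs from compound 3 in one place: 4-(trifluoromethoxy)phenyl in place of 2-chloro-4-fluorophenyl on a carbon with a double bond to nitrogen. The new aryl carries one substituent, like the 4-methoxyphenyl of compound 1 and the 4-(trifluoromethyl)phenyl of compound 2, both of which gave higher numbers than compound 3. The steps of a 4.2-fold lower number from compound 1 to compound 3 (0.62 log units; beyond the scatter) and a 5.1-fold lower number from compound 2 to compound 3 (0.71 log units; beyond the scatter) are the ones that bear on this change, and a return toward those numbers is expected: a modest rise, the step of a 4.6-fold higher number from compound 3 to compound 4 (0.66 log units; beyond the scatter). For compound 4 the expected value in this assay is 600 nM, with a range of 250 nM to 1400 nM.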

Compound 4, half-maximal inhibitory concentration: 590 nM
The estimate for compound 4 lay 1.0-fold (0.01 log units) above the measured number; low and high end bracket the measured number.
By their numbers in this assay, from the lowest: compound 3; then compounds 1, 4 and 2 (each within the scatter of the next).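

In this assay, the 4-(trifluoromethoxy)phenyl of compound 4 falls in with the other aryl groups carrying one substituent, with no separation from the trifluoromethyl or methoxy analogues (a 1.1-fold lower number from compound 2 to compound 4 (0.05 log units; within the scatter)) and (a 1.1-fold higher number from compound 1 to compound 4 (0.04 log units; within the scatter)). Set against the 2-chloro-4-fluorophenyl (a 4.5-fold higher number from compound 3 to compound 4 (0.66 log units; beyond the scatter)), it leaves compound 3 as the only compound set apart at this position, so the lower number rests on that single aryl group, while three different para-free descriptions of one substituent give no spread. No measurement on hand accounts for this difference.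

Still open, going by these compounds, is whether the chlorine, the fluorine or the pair accounts for the lower number of compound 3. Equally open, on these data alone, is how this position responds to an aryl group carrying an amine or a carboxylic acid.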